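A few compounds are considered here, and "the series" means these few. Any claim that something is new, unique, unknown or untested is made for them only; others in the source may bear on it.

Three compounds that share a core have been examined in an assay on membranes from lung (Cavia porcellus) for binding affinity to cysteinyl leukotriene receptor (Homo sapiens); on this read-out lower numbers stand for stronger inhibition and higher numbers for weaker inhibition. Compound 1 `O=C(O)CC1CCCC1Cc1ccc(OCc2ccc3ccccc3n2)cc1` gives 100 nM. Compound 2 `CC(CCC(=O)O)Cc1cccc(OCc2ccc3ccccc3n2)c1` gives 140 nM, the highest of the three numbers, although its gap to compound 1 lies within the usual scatter of repeated measurements. Compound 3 `CC(CCc1nnn[nH]1)Cc1ccc(OCc2ccc3ccccc3n2)cc1` gives 12 nM, and its gap to compound 2 lies beyond that scatter. Going by the values given here, only one pair among the measured compounds differs in a single place: an 8.3-fold lower number from compound 1 to compound 3 (0.92 log units; beyond the scatter), where 3-(1H-tetrazol-5-yl)-1-methylpropyl replaces 2-(carboxymethyl)cyclopentyl on a saturated chain carbon bound to an aromatic carbon.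

Compound 4 `CC(Cc1cccc(OCc2ccc3ccccc3n2)c1)CC(C)C(=O)O` has not been measured. It differs from compound 2 by methyl in place of hydrogen on a saturated chain carbon bound to a carbonyl carbon and a saturated chain carbon. Among the compounds with values here, none of the measured steps touches this kind of change; the one measured step alters the acid-bearing end and the chain itself, not a single hydrogen near the carbonyl. With nothing to suggest a direction, the expected change is small: from compound 2 to compound 4, no change at the digits printed from compound 2 to compound 4 (within the scatter) is expected, a step within the scatter. For compound 4 in this assay the expected value is 140 nM, with a likely range from 50 nM to 400 nM.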

Compound 4, inhibition constant: 24 nM
Compound 4: the middle estimate sits 5.8-fold (0.77 log units) above what was measured; the measured number lies below the stated range.
By their numbers in this assay, from the lowest: compounds 3 and 4 (each within the scatter of the next); then compounds 1 and 2 (each within the scatter of the next).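

In this assay, the change of 3-carboxy-1-methylpropyl to 3-carboxy-1-methylbutyl gives a 5.8-fold lower number from compound 2 to compound 4 (0.77 log units; beyond the scatter), a step beyond the scatter. Going by these compounds alone, this shows that the saturated chain carbon bound to a carbonyl carbon responds to the addition of a single carbon atom, something the earlier compounds could not reveal: their only step, an 8.3-fold lower number from compound 1 to compound 3 (0.92 log units; beyond the scatter), exchanged one whole group for another, so it said nothing about this one hydrogen. Nothing measured here gives a reason for the lower number, so the step stands as an observation only.

The compounds shown leave open whether an ethyl group or a second methyl on this same carbon would push the number further down or bring it back up. They also leave open whether methyl in place of hydrogen would give a step of similar size on a chain that ends in 1H-tetrazol-5-yl, as in compound 3, instead of in a carboxylic acid.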